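The compounds below may be only part of what the source reports. "The series", "measured", "known", "first", "only" and "open" are said of these compounds alone.

In a functional assay on A549 cells (Homo sapiens) for antiproliferative activity, read by MTT assay, with a stated time of 96 h (on this read-out lower numbers stand for stronger inhibition of growth and higher numbers for weaker inhibition of growth), compound 1 `Cc1cc(-c2ccc(F)cc2)nn1Cc1ccc(C(=O)NO)cc1` gives 11400 nM and compound 2 `CCCc1cc(-c2ccc(F)cc2)nn1Cc1ccc(C(=O)NO)cc1` gives 15200 nM. Within the data shown here, these are the only two measurements so far, and compound 2 stands level with compound 1 within the usual scatter of repeated measurements.

Compound 3 `CCc1cc(-c2ccc(F)cc2)nn1Cc1ccc(C(=O)NO)cc1` differs from compound 2 in one place, (hydrogen in place of methyl on a saturated chain carbon, two bonds along the chain from an aromatic carbon). In words, this is hydrogen in place of methyl on a saturated chain carbon, two bonds along the chain from an aromatic carbon, so propyl becomes ethyl.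

Among the measured compounds shown here, only one measured step bears on this change: a 1.3-fold higher number from compound 1 to compound 2 (0.12 log units; within the scatter). That step takes the chain from the methyl of compound 1 to the propyl of compound 2, and it stays within the scatter. Ethyl is the intermediate case of these chains, so no change beyond the scatter is expected in this assay. The expected step is a 1.2-fold lower number from compound 2 to compound 3 (0.07 log units; within the scatter), which would also lie within the scatter. For compound 3 the estimated value is 13000 nM, with an expected range of 8000 nM to 21000 nM.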

Compound 3, concentration for 50% growth inhibition: 19200 nM
The estimate for compound 3 lay 1.5-fold (0.17 log units) below the measured number; the measured number falls inside the stated range.
By their numbers in this assay, from the lowest: compounds 1, 2 and 3 (each within the scatter of the next).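

With compound 3, the chain on the shared core now runs through methyl, ethyl and propyl, which gives a third point for judging chain length in this assay. Shortening propyl to ethyl gives a 1.3-fold higher number from compound 2 to compound 3 (0.10 log units; within the scatter) and adding to the methyl chain to reach ethyl gives a 1.7-fold higher number from compound 1 to compound 3 (0.23 log units; within the scatter) and since both steps stay within the scatter, the three chains cannot be told apart here and no trend with chain length can be read from them. Nothing measured alongside these numbers speaks to why the three chains read alike.

As far as these compounds go, all three compounds carry a short unbranched saturated chain at this place, so it remains open whether a longer chain such as hexyl, a branched group such as isopropyl, a ring such as cyclopropyl, or a chain ending in an amine or a carboxylic acid would shift the number beyond the scatter. From the compounds shown here alone, the comparison also rests on a single cell assay, and whether the same flat picture holds on other cells stays open as well.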